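The source may report more compounds than this note shows. Statements on the series, on what has been measured and on what is new or still open speak of the compounds shown alone.

Of the compounds shown here, three of one shared core have been tested in a functional assay on MGC-803 cells (Homo sapiens) for antiproliferative activity, read by CCK-8 assay, with a stated time of 72 h, tested at 2 uM; a higher number here means a stronger effect of the compound at the concentration tested, a lower number a weaker effect. Compound 1 `Nc1ccccc1NC(=O)c1ccc(CSC(=S)N2CCN(c3ccccc3)CC2)cc1` gives 42.3%, the second highest of the three numbers. Compound 2 `CC1CCCCN1C(=S)SCc1ccc(C(=O)Nc2ccccc2N)cc1` gives 64.4%, and compound 3 `CN(Cc1ccncc1)C(=S)SCc1ccc(C(=O)Nc2ccccc2N)cc1` gives 38.1%, a value within the scatter of that of compound 1. Among the measured compounds shown here, the only measured step, a number 26.3 percentage points lower from compound 2 to compound 3 (beyond the scatter), exchanges the whole amine on the thiocarbonyl carbon, so it bears only loosely on the change to compound 4 `Nc1ccccc1NC(=O)c1ccc(CSC(=S)N2CCN(c3ccncc3)CC2)cc1`, which is pyridin-4-yl in place of phenyl on an amine nitrogen in a ring. For the measured compounds named here, no measured step isolates this exchange. Compound 4 is therefore expected to show at most a small change, a number 4.3 percentage points lower from compound 1 to compound 4 (within the scatter), within the usual scatter; its value in this assay is estimated at 38%, with a range from 25% to 52%.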

Compound 4, a percentage reported as inhibition, at one concentration (the size of the read-out at that concentration, not a potency): 64.8%
Estimate against measurement, compound 4: 26.8 percentage points below; the whole stated range lies below it.
By their numbers in this assay, from the lowest: compounds 3 and 1 (each within the scatter of the next); then compounds 2 and 4 (each within the scatter of the next).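

In this assay, pyridin-4-yl in place of phenyl on an amine nitrogen in a ring gives a number 22.5 percentage points higher from compound 1 to compound 4 (beyond the scatter) and so shows that this position responds to a single ring nitrogen at an unchanged count of heavy atoms. The earlier compounds shown here held no step that isolated this exchange. Nothing available accounts for the rise.

The compounds shown leave open whether pyridin-3-yl or pyridin-2-yl at the same place would behave like pyridin-4-yl. A single concentration also leaves the potency of compound 4 open.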